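The source may report more compounds than this note shows. Statements on the series, on what has been measured and on what is new or still open speak of the compounds shown alone.

Of the compounds shown here, two have so far been measured in an assay on isolated protein for displacement of a labelled ligand from metabotropic glutamate receptor 5 (Homo sapiens), with a stated time of 60 min, tested at 1 uM; on this read-out higher numbers stand for more inhibition at the one concentration tested (going by the name of the read-out) and lower numbers for less inhibition. Compound 1 `CC1CCN(c2c(S(=O)(=O)c3ccc(F)c(Cl)c3)cnc3cc(F)ccc23)CC1` gives 94%, while compound 2 `CC1CCN(c2c(S(=O)(=O)c3ccccc3)cnc3cc(F)ccc23)CC1` gives 87%. Among the measured compounds shown here, the single step between them, a number 7 percentage points lower from compound 1 to compound 2 (within the scatter), accompanies phenyl in place of 3-chloro-4-fluorophenyl on a sulfonyl sulfur. On these two numbers compound 2 stands lowest, with compound 1 nearest, though the gap lies within the scatter, so no order between them can be read.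

Compound 3 `CC1CCN(c2c(S(=O)(=O)c3ccc(F)cc3)cnc3cc(F)ccc23)CC1` differs from compound 2 by fluoro in place of hydrogen on an aromatic carbon. For the measured compounds named here, the only measured step that bears on this change is a number 7 percentage points lower from compound 1 to compound 2 (within the scatter), which stayed within the scatter when two halogens left the same ring. A single fluoro entering is therefore expected to move the number little, if at all, with the step estimated as a number 3 percentage points higher from compound 2 to compound 3 (within the scatter) and not beyond the scatter. Compound 3 is estimated to give 90%, within a range from 80% to 97%.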

Compound 3, a percentage reported as inhibition, at one concentration (the size of the read-out at that concentration, not a potency): 74.5%
Compound 3: middle estimate off by 15.5 percentage points, on the high side; the whole stated range lies above it.
By their numbers in this assay, from the lowest: compound 3; then compounds 2 and 1 (each within the scatter of the next).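

The position para to the sulfonyl group's large neighbour on this ring turns out to be sensitive in this assay: fluoro alone there goes with a number 12.5 percentage points lower from compound 2 to compound 3 (beyond the scatter), a change beyond the scatter that the two-halogen comparison had not revealed. Chloro also matters once fluoro is present, since hydrogen in its place goes with a number 19.5 percentage points lower from compound 1 to compound 3 (beyond the scatter), so the 4-fluorophenyl and 3-chloro-4-fluorophenyl groups are clearly separated even though the phenyl and 3-chloro-4-fluorophenyl groups are not. Nothing available explains why these halogens behave in this way.

The compounds shown leave open whether this loss is particular to fluoro or would also follow a methoxy group or a nitrile in the same place. They also leave open what a 3-chlorophenyl group would give.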